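Swapping a Fluorophenyl Cap for tert-Butyl

A few compounds are considered here, and "the series" means these few. Any claim that something is new, unique, unknown or untested is made for them only; others in the source may bear on it.

Compound 1, `CC(C)(C)C[C@@H](O)C(=O)N1[C@@H]2C[C@@H]2C[C@H]1C(=O)NCc1cc(Cl)ccc1-n1cnnn1`, gives 520 nM in a functional assay on a cell-free system (plasma, Homo sapiens), with a stated time of 3 min; on this read-out higher numbers stand for weaker inhibition and lower numbers for stronger inhibition.
Compound 2, `CC1(C[C@@H](O)C(=O)N2N=CC[C@H]2C(=O)NCc2cc(Cl)ccc2-n2cnnn2)CC1`, gives 730 nM in this assay.
Compound 3, `O=C(NCc1cc(Cl)ccc1-n1cnnn1)[C@@H]1C[C@@H]2C[C@@H]2N1C(=O)[C@H](O)c1ccccc1F`, gives 770 nM in this assay.

Among these three, compound 3 carries the highest number. Its nearest neighbour is compound 2, whose value sits within the usual scatter of compound 3's; compound 1 lies furthest away, yet that gap too stays within the scatter. No ranking of the three can therefore be drawn from the figures at hand, and none of them is to be called the strongest or the weakest.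

Compound 4, `CC(C)(C)[C@@H](O)C(=O)N1[C@H](C(=O)NCc2cc(Cl)ccc2-n2cnnn2)C[C@@H]2C[C@@H]21`, has not yet been measured. It differs from compound 3 in one place: tert-butyl in place of 2-fluorophenyl on a saturated chain carbon bound to a carbonyl carbon and an oxygen on a saturated carbon. Among the compounds with values here, compound 1, with a saturated group at a similar spot, gives 520 nM, a number that does not separate from compound 3 beyond the scatter, so the measured pairs offer no step that would point firmly in either direction.

The writer therefore expects the move from compound 3 to compound 4 to be a small step toward a lower number, of a size that could still fall within the scatter, a 1.7-fold lower number from compound 3 to compound 4 (0.23 log units; within the scatter). For compound 4 the estimated value in this assay is 450 nM, with a range from 180 nM to 1100 nM.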

Compound 4, half-maximal inhibitory concentration: 1500 nM
Compound 4: middle estimate off by 3.3-fold (0.52 log units), on the low side, outside the stated range (above it).
By their numbers in this assay, from the lowest: compounds 1, 2, 3 and 4 (each within the scatter of the next, the first and the last beyond it).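

Replacing 2-fluorophenyl with tert-butyl on a saturated chain carbon bound to a carbonyl carbon and an oxygen on a saturated carbon gives, in this assay, a 1.9-fold higher number from compound 3 to compound 4 (0.29 log units; within the scatter), and this is the first step among the compounds shown that differs in one place only. A six-membered aromatic ring of carbon is therefore not needed at this place for a value within the scatter of compound 3, since tert-butyl, with no ring and fewer heavy atoms, cannot be told apart from 2-fluorophenyl on this read-out. Nothing at hand offers an explanation for this step.

From the compounds shown here alone, it remains open whether another group at this place, such as a methyl, a cyclohexyl or an unsubstituted phenyl, would separate from these two beyond the scatter, and whether an amine in place of the oxygen would do so. Going by these compounds, it is also open whether the same exchange would give a step of similar size on another core, such as the core of compound 2.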